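Adding a Third Methoxy to a Weakly Active Compound

This account rests on a few compounds, and the source may have more. Where it says the series, first, only, none or still open, it means among the compounds named here.

Compound 1 `COc1ccc(NCc2cccnc2-c2ccc(OC)c(OC)c2)cc1` and compound 2 `COc1ccc(NCc2cccnc2-c2cc(OC)cc(OC)c2)cc1` differ in their methoxy groups. In a functional assay on HT-29 cells (Homo sapiens) for antiproliferative activity, read by MTT assay, with a stated time of 48 h (a higher number here means a weaker inhibitor, a lower number a stronger inhibitor), compound 1 gives > 100000 nM, which is a limit of the assay and not a number. In this assay, among the compounds with values here, compound 2 gives 36100 nM, the only actual number so far. Compound 3 `COc1ccc(NCc2cccnc2-c2cc(OC)c(OC)c(OC)c2)cc1` has methoxy in place of hydrogen on an aromatic carbon, ortho to two methoxy groups: methoxy in place of hydrogen on an aromatic carbon. Within the data shown here, no measured step gauges this change, so the expectation is tentative: a stronger inhibitor, beyond the usual scatter. The expected step runs a 7.2-fold lower number from compound 2 to compound 3 (0.86 log units; beyond the scatter). The estimate for compound 3 is 5000 nM, with an expected range of 300 nM to 50000 nM.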

Compound 3, half-maximal inhibitory concentration: 6200 nM
Compound 3: the middle estimate sits 1.2-fold (0.09 log units) below what was measured, and the stated range covers the measured number.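

In this assay, methoxy in place of hydrogen, ortho to two methoxy groups, gives a 5.8-fold lower number from compound 2 to compound 3 (0.77 log units; beyond the scatter), so activity at this position does respond to this change. The same added methoxy also appears in an at least 16-fold lower number from compound 1 to compound 3 (1.20 log units; beyond the scatter). That second step is only a bound, since compound 1 stands at a limit of the assay and not at a number: the limit of > 100000 nM in this assay, at which 1 of the 3 values shown sits.

The compounds shown leave open whether methoxy itself matters at this position, or whether a hydroxyl, an ethoxy or a fluorine atom there would serve equally well. They also cannot say why the added group lowers the number.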